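The source may report more compounds than this note shows. Statements on the series, on what has been measured and on what is new or still open speak of the compounds shown alone.

Measured compounds in a functional assay on NCI/ADR-RES cells (Homo sapiens) for inhibition, read by sulforhodamine B assay, with a stated time of 48 h, tested at 10 uM; on this read-out higher numbers stand for more inhibition at the one concentration tested (going by the name of the read-out) and lower numbers for less inhibition:
Compound 1, `c1ccc(-c2cn3ccnc3c(-c3ccc4ncn(C5CCCCC5)c4c3)n2)cc1`, gives 50.5%.
Compound 2, `c1ccc2c(-c3cn4ccnc4c(-c4ccc5ncn(C6CCCCC6)c5c4)n3)cccc2c1`, gives 4.43%.
Compound 3, `CC(=O)c1ccc(-c2cn3ccnc3c(-c3ccc4ncn(C5CCCCC5)c4c3)n2)cc1`, gives 4.17%.

Among these three numbers in this assay compound 2 holds the second highest. Its nearest neighbour is compound 3, separated by a number 0.3 percentage points lower from compound 2 to compound 3 (within the scatter), so the two cannot be told apart. Its furthest neighbour is compound 1, from which it is reached by a number 46.1 percentage points lower from compound 1 to compound 2 (beyond the scatter); the parallel step a number 46.3 percentage points lower from compound 1 to compound 3 (beyond the scatter) is of the same size.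

Compound 4, `c1ccc(Cn2cnc3ccc(-c4nc(-c5cccc6ccccc56)cn5ccnc45)cc32)cc1`, differs from compound 2 in one place: benzyl in place of cyclohexyl on an aromatic nitrogen. Within the data shown here, every measured step changes the aryl group attached to the aromatic carbon; no measured step touches the group on the aromatic nitrogen of the fused five-membered ring. The closest guidance is that compound 2 and compound 3, which share that cyclohexyl group, lie within the scatter of each other at the low end of the range, so the substituent on the nitrogen has not yet been shown to move the number at all.

The expectation for compound 4 is therefore a step from compound 2 of a number 2.6 percentage points higher from compound 2 to compound 4 (within the scatter), that is, none beyond the scatter. Compound 4 is estimated at 7%, with a range from 0% to 30%.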

Compound 4, a percentage reported as inhibition, at one concentration (the size of the read-out at that concentration, not a potency): 5.83%
Compound 4: middle estimate off by 1.2 percentage points, on the high side, within the range that was stated.
By their numbers in this assay, from the lowest: compounds 3, 2 and 4 (each within the scatter of the next); then compound 1.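

In this assay, among these compounds, the step of a number 1.4 percentage points higher from compound 2 to compound 4 (within the scatter) is the first measured change on the aromatic nitrogen of the five-membered aromatic ring, where benzyl, with its six-membered aromatic ring of carbon only, takes the place of cyclohexyl, with its six-membered non-aromatic ring of carbon only. With naphthalen-1-yl held on the aromatic carbon, exchanging one of these groups for the other leaves compound 4 indistinguishable from compound 2, so at this position and in this setting, the aromatic or non-aromatic nature of the ring has no readable effect on the number. Nothing in hand explains this outcome.

From the compounds shown here alone, both compounds in this comparison carry naphthalen-1-yl, so it remains open whether benzyl would also leave the number unchanged on the phenyl compound, where compound 1 gives 50.5% and there is more room to see a fall. Going by these compounds, both groups on the nitrogen also contain carbon only, and it remains open whether a chain ending in an amine, or one ending in a carboxylic acid, would move the number at this position.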